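From morpholin-4-yl to pyrrolidin-1-yl on a carbonyl carbon

The source may report more compounds than this note shows. Statements on the series, on what has been measured and on what is new or still open speak of the compounds shown alone.

- compound 1 `COc1cc(N2CCN(C(=O)C3CCC(O)CC3)CC2)ccc1Nc1nc(NC2CCCCC2)c2nc[nH]c2n1`: 19000 nM
- compound 2 `COc1cc(N2CCN(Cc3ccccn3)CC2)ccc1Nc1nc(NC2CCCCC2)c2nc[nH]c2n1`: 38000 nM
- compound 3 `COc1cc(N2CCC(CC(=O)N3CCOCC3)CC2)ccc1Nc1nc(NC2CCCCC2)c2nc[nH]c2n1`: 19000 nM

In a physicochemical assay for solubility, measured as kinetic solubility, at pH 7.4 (a higher number here means a more soluble compound, a lower number a less soluble compound), compound 3 reads 19000 nM, level with compound 1 and within the scatter of compound 2. Compound 4 `COc1cc(N2CCC(CC(=O)N3CCCC3)CC2)ccc1Nc1nc(NC2CCCCC2)c2nc[nH]c2n1` differs from compound 3 in one place: pyrrolidin-1-yl in place of morpholin-4-yl on a carbonyl carbon; in short, pyrrolidin-1-yl in place of morpholin-4-yl on a carbonyl carbon. Among the compounds with values here, no measured step makes this change. Within the data shown here, the only measured step, a 2.0-fold higher number from compound 1 to compound 2 (0.30 log units; within the scatter), concerns a different group, on an amine nitrogen in a ring, so it offers only weak guidance. No change beyond the scatter is therefore expected in this assay. The expected step is a 1.2-fold lower number from compound 3 to compound 4 (0.07 log units; within the scatter). Compound 4 is estimated at 16000 nM, with an expected range of 7000 nM to 35000 nM.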

Compound 4, solubility: 19000 nM
Compound 4: middle estimate off by 1.2-fold (0.07 log units), on the low side; the measured number falls inside the stated range.
By their numbers in this assay, from the lowest: compounds 1, 3, 4 and 2 (each within the scatter of the next).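

In this assay, pyrrolidin-1-yl in place of morpholin-4-yl on this carbonyl carbon gives no change at the digits printed from compound 3 to compound 4 (within the scatter). Within the data shown here, this is the only measured change at this place, and it shows that the reading holds when the ring oxygen is lost and the ring shrinks from six members to five. No measurement here explains why the reading holds. Going by these compounds, whether a different kind of group on this carbonyl carbon, such as an open-chain dimethylamino group or a ring carrying a carboxylic acid, would shift the reading remains open.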